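A few compounds are considered here, and "the series" means these few. Any claim that something is new, unique, unknown or untested is made for them only; others in the source may bear on it.

The measured compounds, all tested in a functional assay on SNB-75 cells (Homo sapiens) for cytotoxicity, read by sulforhodamine B assay, with a stated time of 48 h; a lower number here means a stronger inhibitor of growth, a higher number a weaker inhibitor of growth:
Compound 1 `ClCc1cccc(Cn2cnc3ncnc(Cl)c32)c1` gives 1860 nM.
Compound 2 `ClCc1ccccc1Cn1cnc2ncnc(Cl)c21` gives 11200 nM.
Compound 3 `ClCc1cccc(Cn2cnc3nc(Cl)nc(Cl)c32)c1` gives 1090 nM.

Compounds 1 and 2 are built from the same atoms joined differently; how their two cores differ is not broken down here. In this assay compound 2 has the highest number of the three, and its gaps to compound 1 and to compound 3 both lie beyond the scatter, so compound 2 is the weakest inhibitor of growth in this set.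

Compound 3 differs from compound 1 in one place: chloro in place of hydrogen on an aromatic carbon. The step this made, a 1.7-fold lower number from compound 1 to compound 3 (0.23 log units; within the scatter), is within the scatter, so on this pair alone the added chloro group cannot be said to have changed anything.

Compound 4 `ClCc1ccccc1Cn1cnc2nc(Cl)nc(Cl)c21` is not yet measured. It differs from compound 2 by chloro in place of hydrogen on an aromatic carbon, the same change as from compound 1 to compound 3, at a place described in the same words. For the measured compounds named here, only one measured example of this change exists, so the expectation rests on that single pair. The expected step is a 1.7-fold lower number from compound 2 to compound 4 (0.23 log units; within the scatter), because the earlier step was a 1.7-fold lower number from compound 1 to compound 3 (0.23 log units; within the scatter) and nothing shows why the second core should respond differently. The estimate for compound 4 in this assay is 6600 nM, with most repeat measurements expected to fall from 2500 nM to 18000 nM.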

Compound 4, concentration for 50% growth inhibition: 1900 nM
Compound 4: middle estimate off by 3.5-fold (0.54 log units), on the high side, outside the stated range (below it).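

In this assay putting a chloro group in place of hydrogen on the core of compound 2 gave a 5.9-fold lower number from compound 2 to compound 4 (0.77 log units; beyond the scatter) and this step, unlike the earlier one, lies beyond the scatter. This shows that a step measured on one core in this series cannot simply be copied onto the other, since even a change of a single atom need not give a step of the same size on both. It does not show why the two cores respond differently, and with only two pairs it cannot show how a further core would respond, but the comparison of the two steps is clear enough on its own terms: the same change on two cores in this assay, a 1.7-fold lower number (0.23 log units; within the scatter) from compound 1 to compound 3 and a 5.9-fold lower number (0.77 log units; beyond the scatter) from compound 2 to compound 4, 3.5-fold (0.54 log units) apart, beyond the scatter of two such steps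

The compounds shown leave open whether the larger step on the core of compound 2 is particular to chloro, since no other group, such as fluoro, an amine or a methoxy group, appears on the aromatic carbon between two ring nitrogen atoms. They also leave open whether replacing the chloromethyl group with a longer chain or a hydroxymethyl group would alter how either core responds to this change.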